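The source may hold more compounds than are shown below. What is called first, only, known or untested is meant among the compounds shown, and "the series" means these compounds.

So far, two compounds built on a shared core have numbers. In a functional assay on SGC-7901 cells (Homo sapiens) for antiproliferative activity, read by MTT assay, with a stated time of 24 h (on this read-out lower numbers stand for stronger inhibition and higher numbers for weaker inhibition), compound 1 (`O=C(NNc1ccccc1F)c1ccc(NS(=O)(=O)c2cnc(O)nc2O)cc1`) gives 16000 nM and compound 2 (`CCCCOc1ccc(C(=O)NNC(=O)c2ccc(NS(=O)(=O)c3cnc(O)nc3O)cc2)cc1`) gives 14700 nM and so stands within the scatter of compound 1, with neither ranked above the other.

The next compound, compound 3 (`Cc1ccccc1C(=O)NNC(=O)c1ccc(NS(=O)(=O)c2cnc(O)nc2O)cc1`), keeps the core of compound 2 and changes only the group on a carbonyl carbon whose other neighbour is an amide-type nitrogen (2-methylphenyl in place of 4-butoxyphenyl on a carbonyl carbon). Here 2-methylphenyl comes in place of 4-butoxyphenyl.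

Among the measured compounds shown here, no measured pair shows what this swap does, so the guidance is thin. Compound 1 at 16000 nM and compound 2 at 14700 nM carry different groups on the shared core and still fall within the scatter of each other, and that is the only hint available. On that weak basis, no step beyond the scatter is expected in this assay and no direction is favoured. The estimated step of a 1.0-fold higher number from compound 2 to compound 3 (0.01 log units; within the scatter) is expected to stay small. Compound 3 is estimated at 15000 nM with an expected range from 6000 nM to 40000 nM across repeat measurements.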

Compound 3, half-maximal inhibitory concentration: > 20000 nM
Compound 3: no number, only a limit; the forecaster's own chance of this, stated with the estimate: 8%; at least 1.3-fold (0.12 log units) between middle value and limit.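

In this assay compound 3 has only a limit, > 20000 nM, and not a number. Placing 2-methylphenyl in place of 4-butoxyphenyl on a carbonyl carbon gives an at least 1.3-fold higher number from compound 2 to compound 3 (0.13 log units; that floor lies within the scatter), the first step at this position between compounds that differ in one place; it shows that this swap does not bring a lower number, though its floor does not go beyond the scatter. The wider change, (2-methylphenyl)carbonyl in place of 2-fluorophenyl on an amine nitrogen, gives an at least 1.2-fold higher number from compound 1 to compound 3 (0.09 log units; that floor lies within the scatter), and this floor also stays within the scatter, so the true size of both steps remains unknown: the limit of > 20000 nM in this assay, at which 1 of the 3 values shown sits.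

The compounds shown leave open whether 2-methylphenyl truly weakens the effect, and by how much, since only a measured number for compound 3 could settle that. They also leave open what other groups would do on this carbonyl carbon, such as a phenyl ring carrying an amine or a carboxylic acid, or one carrying a longer chain than butoxy.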